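Aryl swap on the ring nitrogen of a sulfonamide series

The source may report more compounds than this note shows. Statements on the series, on what has been measured and on what is new or still open speak of the compounds shown alone.

Measured compounds in a functional assay on HT-29 cells (Homo sapiens) for antiproliferative activity; on this read-out lower numbers stand for stronger inhibition and higher numbers for weaker inhibition:
compound 1 `COc1ccc(S(=O)(=O)N2CCc3cccc(Nc4ccc(Cl)cc4)c32)cc1`: 658 nM
compound 2 `COc1ccc(S(=O)(=O)N2CCc3cccc(Nc4ccc(F)c(F)c4)c32)cc1`: 968 nM

Compound 2 and compound 1 stand within the scatter of each other in this assay: a 1.5-fold higher number from compound 1 to compound 2 (0.17 log units; within the scatter). That step, the only one on record, changes the aryl group on the same nitrogen as the change to compound 3 `COC(=O)c1ccc(Nc2cccc3c2N(S(=O)(=O)c2ccc(OC)cc2)CC3)cc1`, and it stayed within the scatter. Change now: 4-(methoxycarbonyl)phenyl in place of 3,4-difluorophenyl on a nitrogen on an aromatic ring. With one within-scatter precedent, no step beyond the scatter is expected in either direction, so a 1.1-fold lower number from compound 2 to compound 3 (0.03 log units; within the scatter) is estimated, and compound 3 is expected to give about 900 nM in this assay, between 300 nM and 2700 nM.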

Compound 3, half-maximal inhibitory concentration: 678 nM
Beside the measured number, compound 3's estimate is 1.3-fold (0.12 log units) above it; low and high end bracket the measured number.
By their numbers in this assay, from the lowest: compounds 1, 3 and 2 (each within the scatter of the next).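

In this assay, 4-(methoxycarbonyl)phenyl on a nitrogen on an aromatic ring, with 2 hydrogen-bond acceptors against 0 for 3,4-difluorophenyl, gives a 1.4-fold lower number from compound 2 to compound 3 (0.15 log units; within the scatter) and so adds a second within-scatter step at this position. Methoxycarbonyl in place of chloro on an aromatic carbon gives a 1.0-fold higher number from compound 1 to compound 3 (0.01 log units; within the scatter) as well, so the three aryl groups shown cannot be told apart on this read-out. No evidence is available that bears on these results.

As far as these compounds go, whether a carboxylic acid or an amine in place of methoxycarbonyl would move the number beyond the scatter stays open.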